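Changing the Aryl Group on the Shared Core

This account rests on a few compounds, and the source may have more. Where it says the series, first, only, none or still open, it means among the compounds named here.

Measured compounds in this study:
compound 1 `COc1ccc(F)cc1CNCCCNc1ccnc2cc(Cc3cc(C)cc(C)c3)ccc12`: 940 nM
compound 2 `Fc1ccc(-c2ccc3c(NCCCNCc4ccco4)ccnc3c2)cc1`: 7760 nM
compound 3 `Cc1cc(C)cc(Cc2ccc3c(NCCCNCc4ccco4)ccnc3c2)c1`: 6270 nM

In an ADME assay on HepG2 cells (Homo sapiens) for cytotoxicity, read by luminescence, CellTiter-Glo and ATP content, with a stated time of 72 h (a higher number here means that more compound is needed for the effect, a lower number that less compound is needed), compound 1 gives 940 nM, the lowest of the three numbers. Its nearest neighbour is reached by a 6.7-fold higher number from compound 1 to compound 3 (0.82 log units; beyond the scatter), and compound 2 lies furthest away at 7760 nM.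

Compound 4 `COc1ccc(F)cc1CNCCCNc1ccnc2cc(-c3ccc(C(C)(C)C)cc3)ccc12` differs from compound 1 at a single place: 4-(tert-butyl)phenyl in place of 3,5-dimethylbenzyl on an aromatic carbon

Among the measured compounds shown here, only one measured step touches this same aromatic carbon of the core: a 1.2-fold lower number from compound 2 to compound 3 (0.09 log units; within the scatter), a change that stayed within the scatter. The other step, a 6.7-fold higher number from compound 1 to compound 3 (0.82 log units; beyond the scatter), concerns the saturated chain carbon bound to the amine nitrogen and does not bear on the present change. For the measured compounds named here, since the one comparison at this position moved little, and compound 4 keeps the 5-fluoro-2-methoxyphenyl side of compound 1 that accompanies the low number of compound 1, the expectation for compound 4 is a step of a 1.1-fold lower number from compound 1 to compound 4 (0.04 log units; within the scatter), which is not beyond the scatter. Compound 4 is therefore estimated at 850 nM, with a likely range from 350 nM to 2100 nM.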

Compound 4, half-maximal effective concentration: 620 nM
Estimate against measurement, compound 4: 1.4-fold (0.14 log units) above; measured number inside the range.
By their numbers in this assay, from the lowest: compounds 4 and 1 (each within the scatter of the next); then compounds 3 and 2 (each within the scatter of the next).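

In this assay, with the 5-fluoro-2-methoxyphenyl side held fixed, replacing 3,5-dimethylbenzyl with 4-(tert-butyl)phenyl gives a 1.5-fold lower number from compound 1 to compound 4 (0.18 log units; within the scatter) and leaves the number unchanged within the scatter. Among the compounds shown here, the only earlier comparison at this aromatic carbon, a 1.2-fold lower number from compound 2 to compound 3 (0.09 log units; within the scatter), came from compounds carrying furan-2-yl on the side chain, so the result extends the same flat reading to a second side chain and to a different pair of carbon-only aromatic groups. Across these two steps, no compound goes against that reading, although both exchanges keep one six-membered aromatic ring of carbon only and no hydrogen-bond donors or acceptors in the group, and no measurement shown offers an explanation for the flat response.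

The compounds shown leave open whether an amine, a carboxylic acid or a pyridine ring at this aromatic carbon would keep the number in the same range. As far as these compounds go, it also remains open whether the side-chain step seen as a 6.7-fold higher number from compound 1 to compound 3 (0.82 log units; beyond the scatter) would recur if furan-2-yl were paired with 4-(tert-butyl)phenyl on the shared core.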